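Methyl for trifluoromethyl on the shared core

The source may report more compounds than this note shows. Statements on the series, on what has been measured and on what is new or still open speak of the compounds shown alone.

The series shares the core of compound 1 `Nc1nc2ccccn2c1-c1ccc(O)cc1`. In an assay on isolated protein for inhibition of ubiquitin carboxyl-terminal hydrolase 1 (Homo sapiens) (on this read-out higher numbers stand for weaker inhibition and lower numbers for stronger inhibition), compound 1 gives only a limit, > 100000 nM. Compound 2 `COc1ccc(-c2c(N)nc3ccccn23)cc1` carries methyl in place of hydrogen on an oxygen on an aromatic ring; in this assay compound 2 also gives only a limit, > 100000 nM. Compound 3 `Nc1nc2ccc(C(F)(F)F)cn2c1-c1ccc(O)cc1` carries trifluoromethyl in place of hydrogen on an aromatic carbon; in this assay compound 3 likewise gives only a limit, > 100000 nM. Accordingly a step that the two limits leave unreadable from compound 1 to compound 2 and a step that the two limits leave unreadable from compound 1 to compound 3. Compound 3 thus stands at the limit of > 100000 nM in this assay, at which 3 of the 3 values shown sit, with no number of its own.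

Compound 4 `Cc1ccc2nc(N)c(-c3ccc(O)cc3)n2c1` differs from compound 3 by methyl in place of trifluoromethyl on an aromatic carbon. For the measured compounds named here, both measured steps that bear on compound 3 are unreadable, so neither a size nor a direction can be drawn from them, and no measured step exchanges trifluoromethyl for methyl. The estimate for compound 4 in this assay is 150000 nM, with a range from 30000 nM to 1000000 nM, most likely reported again as a limit. The expected step is a step that the limit leaves unreadable from compound 3 to compound 4, none beyond the scatter in either direction.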

Compound 4, half-maximal inhibitory concentration: > 100000 nM
Compound 4: a limit, no number (the forecaster's own chance of this, stated with the estimate: 85%); the middle value is on the limit's open side.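

Compound 4 gives only a limit, so neither the step from compound 3 to compound 4 nor the step from compound 1 to compound 4 can be read: the limit of > 100000 nM in this assay, at which 4 of the 4 values shown sit.

The compounds shown leave open whether any change on the shared core yields a readable number.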